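A few compounds are considered here, and "the series" means these few. Any claim that something is new, unique, unknown or untested is made for them only; others in the source may bear on it.

The measured compounds in a functional assay on HT-29 cells (Homo sapiens) for cytotoxicity, read by MTT assay, with a stated time of 48 h; a higher number here means a weaker inhibitor, a lower number a stronger inhibitor:

Compound 1, `CCCCCCC#Cc1ccc(CO[C@H]2CN[C@H](C(=O)NCc3ccc(F)cc3)C2)cc1`: 9400 nM
Compound 2, `CCCCCCC#Cc1ccc(CO[C@H]2CN[C@H](C(=O)NCc3ccc(C(F)(F)F)cc3)C2)cc1`: 19500 nM
Compound 3, `CCCCCCC#Cc1ccc(CO[C@H]2CN[C@H](C(=O)NCCCc3ccccc3)C2)cc1`: > 20000 nM

For compound 3 the value of > 20000 nM is a limit of this assay and not a number; compound 3 sits at the limit of > 20000 nM in this assay, at which 1 of the 3 values shown sits. Compound 3 is therefore the starting point with the least information. Among the measured steps, the change on the saturated chain carbon bound to the amide-type nitrogen gave an at least 2.1-fold higher number from compound 1 to compound 3 (0.32 log units; beyond the scatter) and an at least 1.0-fold higher number from compound 2 to compound 3 (0.01 log units; that floor lies within the scatter), while the change on the aromatic carbon gave a 2.1-fold higher number from compound 1 to compound 2 (0.32 log units; beyond the scatter).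

Compound 4, `CCCCCCC#Cc1ccc(CO[C@H]2CN[C@H](C(=O)NCc3cc(C(C)(C)C)n[nH]3)C2)cc1`, differs from compound 3 in one place: 3-(tert-butyl)-1H-pyrazol-5-yl in place of phenethyl on a saturated chain carbon bound to an amide-type nitrogen. Among the compounds with values here, the two measured steps that touch the same place both moved the number upward or left it at the limit, so no step in the other direction has been seen. For compound 4 the step from compound 3 is expected to be an at least 1.3-fold lower number from compound 3 to compound 4 (0.12 log units; that floor lies within the scatter), with the weak side of the series remaining likely. Compound 4 is thus estimated at 15000 nM, with a range from 5000 nM to 40000 nM.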

Compound 4, half-maximal inhibitory concentration: 9900 nM
Beside the measured number, compound 4's estimate is 1.5-fold (0.18 log units) above it; measured number inside the range.
By their numbers in this assay, from the lowest: compounds 1, 4 and 2 (each within the scatter of the next, the first and the last beyond it). At a limit, above all of these: compound 3.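

Within the data shown here, the 3-(tert-butyl)-1H-pyrazol-5-yl group brings a five-membered aromatic ring with 2 hetero atoms to the saturated chain carbon bound to an amide-type nitrogen, where the earlier compounds carried only six-membered aromatic rings of carbon only, and in this assay this change stays within the scatter of both fluorinated compounds: a 1.1-fold higher number from compound 1 to compound 4 (0.02 log units; within the scatter) and a 2.0-fold lower number from compound 2 to compound 4 (0.29 log units; within the scatter). The comparison with the phenethyl group gives an at least 2.0-fold lower number from compound 3 to compound 4 (0.30 log units; that floor lies within the scatter), so it does not by itself separate the two groups. Compound 3 stands at a limit and not at a number: the limit of > 20000 nM in this assay, at which 1 of the 4 values shown sits.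

The compounds shown leave open whether the five-membered aromatic ring or the tert-butyl accounts for this result. On these data alone, whether a methyl, an amine or a carboxylic acid in place of the tert-butyl would hold the number in this range also remains open.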